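Adding a Methyl Beside the Amide Carbonyl

A few compounds are considered here, and "the series" means these few. Any claim that something is new, unique, unknown or untested is made for them only; others in the source may bear on it.

Three compounds share one core, an acid-bearing head attached through an amide to an aryl ether tail, and all have been tested in a functional assay on CHO cells for agonist activity at Free fatty acid receptor 1 (Homo sapiens), read by FLIPR; on this read-out higher numbers stand for an effect only at larger amounts of compound and lower numbers for an effect already at smaller amounts. Compound 1 `CC(Oc1ccccc1)C(=O)Nc1ccc(OCC(=O)O)c(F)c1` gives 135 nM in this assay. Compound 2 `CC(C)c1cccc(OCC(=O)Nc2ccc(OCC(=O)O)c(F)c2)c1` gives 116 nM. Compound 3 `CC(C)(C)c1cccc(OCC(=O)Nc2ccc(OCC(=O)O)c(F)c2)c1` gives 122 nM, which sits second highest of the three numbers, with compound 2 nearest and compound 1 furthest, both within the scatter of the assay.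

Compound 4 `CC(Oc1cccc(C(C)(C)C)c1)C(=O)Nc1ccc(OCC(=O)O)c(F)c1` has not yet been measured. It differs from compound 3 by methyl in place of hydrogen on a saturated chain carbon bound to a carbonyl carbon and an oxygen on an aromatic ring. Within the data shown here, no measured pair isolates exactly this change. Among the measured compounds shown here, the one single-point step on record, a 1.1-fold higher number from compound 2 to compound 3 (0.02 log units; within the scatter), concerns a different position and shows that adding a methyl there left the number essentially unchanged. Compound 1 already carries the methyl that enters in compound 4, though on a shorter tail, and its value lies close to that of compound 3.

From this, the step from compound 3 to compound 4 is expected to stay within the scatter, estimated as a 1.0-fold higher number from compound 3 to compound 4 (0.01 log units; within the scatter). Compound 4 is therefore expected to give about 125 nM in this assay, with a plausible range from 60 nM to 260 nM.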

Compound 4, half-maximal effective concentration in the Free fatty acid receptor 1 assay: 140 nM
The estimate for compound 4 lay 1.1-fold (0.05 log units) below the measured number, and the stated range covers the measured number.
By their numbers in the Free fatty acid receptor 1 assay, from the lowest: compounds 2, 3, 1 and 4 (each within the scatter of the next).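

Among these compounds, in the Free fatty acid receptor 1 assay compound 3 gives 122 nM and compound 4 gives 140 nM; the methyl on the saturated chain carbon bound to a carbonyl carbon and an oxygen on an aromatic ring gives a 1.1-fold higher number from compound 3 to compound 4 (0.06 log units; within the scatter) and so stays within the scatter, which is the first direct reading of this position, since the earlier step concerned a methyl elsewhere. The tert-butyl on an aromatic carbon, read here with that methyl already in place, gives a 1.0-fold higher number from compound 1 to compound 4 (0.02 log units; within the scatter) in the Free fatty acid receptor 1 assay and also stays within the scatter, so neither single change in the tail separates these compounds on this read-out. In a physicochemical assay for lipophilicity, using the shake flask method, at pH 7.4 (a higher number here means a more lipophilic compound, a lower number a more polar compound), compound 3 gives 0.35 and compound 4 gives 0.63; the same methyl gives a number 0.28 log units higher from compound 3 to compound 4 (within the scatter) and again remains within the scatter, and no supporting evidence is available to say why these numbers stay so close.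

Going by these compounds, what an ethyl, a hydroxyl or an amine on this same saturated chain carbon would do stays open, as does a second methyl there. Also open, on these data alone, is whether the methyl would stay within the scatter on a tail carrying a group other than tert-butyl on the aromatic carbon, such as a trifluoromethyl or a methoxy.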